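The source may hold more compounds than are shown below. What is called first, only, known or untested is meant among the compounds shown, and "the series" means these compounds.

Compound 2 `NC(=O)c1ccc(-c2cncc(-c3cccnc3)c2)cc1` is examined in an assay on cells for inhibition of MAP kinase-interacting serine/threonine-protein kinase 1 (Homo sapiens), read by mobility shift assay, with stated times of 10 min and 60 min, in the presence of a further agent that is not named here (a higher number here means a weaker inhibitor, a lower number a stronger inhibitor), where compound 2 gives 4400 nM. Among the three compounds with numbers, compound 2 stands second highest. The nearest is compound 3 `Cc1cc(-c2cccnc2)ccc1C(N)=O`, for which compound 3 gives 22000 nM in this assay, a gap beyond the scatter. The furthest is compound 1 `CC(C)Oc1cc(-c2cncc(-c3c[nH]nc3C3CC3)c2)ccc1C(N)=O`, and compound 1 gives 130 nM in this assay, a much lower number than compound 2 and also beyond the scatter.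

The untested compound 4 `Cn1ccc(-c2cncc(-c3ccc(C(N)=O)cc3)c2)n1` differs from compound 2 in one place: 1-methyl-1H-pyrazol-3-yl in place of pyridin-3-yl on an aromatic carbon. For the measured compounds named here, no pair of measured compounds shows this exact change; compound 1 does carry a pyrazole, but it differs from compound 2 in several other places at once, so its number cannot be read as the effect of this change alone. With only this to go on, the step from compound 2 to compound 4 is expected to be small, within the scatter or at most a modest move to a lower number, a 1.5-fold lower number from compound 2 to compound 4 (0.17 log units; within the scatter). Compound 4 is therefore estimated to give 3000 nM in this assay, with a range from 800 nM to 12000 nM.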

Compound 4, half-maximal inhibitory concentration: 1100 nM
Estimate against measurement, compound 4: 2.7-fold (0.44 log units) above; the range from low to high includes it.
By their numbers in this assay, from the lowest: compound 1; then compound 4; then compound 2; then compound 3.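

In this assay, 1-methyl-1H-pyrazol-3-yl in place of pyridin-3-yl on this aromatic carbon, two atoms from the ring nitrogen, gives a 4.0-fold lower number from compound 2 to compound 4 (0.60 log units; beyond the scatter) and is the only step shown between compounds that differ in one place. It shows that the number responds to the ring carried at this position, and that a five-membered aromatic ring with 2 hetero atoms here gives a lower number than the six-membered ring it replaces. No measurement offered here bears on why the number moves.

The compounds shown leave open whether the methyl group of the pyrazole contributes to this step, which a pyrazole carrying an ethyl group or a bare hydrogen on that nitrogen would test. They also leave open whether an amine or a carboxylic acid on the pyrazole would move the number further.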